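The source may report more compounds than this note shows. Statements on the series, on what has been measured and on what is new or still open speak of the compounds shown alone.

Working notes on the series. In an assay on tissue (PBMC cells) for agonist activity at Toll-like receptor 8 (Homo sapiens), with a stated time of 24 h (on this read-out higher numbers stand for an effect only at larger amounts of compound and lower numbers for an effect already at smaller amounts), compound 1 `CCC[C@H](CO)Nc1nc(N)nc2cccnc12` gives 19000 nM, and compound 2 `CCCC[C@H](CCO)Nc1nc(N)nc2cccnc12` gives 4300 nM, the lower of the two numbers, with compound 1 standing above it by a margin beyond the scatter. Compound 3 `CCCC[C@@H](Nc1nc(N)nc2cccnc12)C(=O)NC` is not yet measured; it carries methylcarbamoyl in place of 2-hydroxyethyl on a saturated chain carbon bound to a nitrogen on an aromatic ring and a saturated chain carbon. For the measured compounds named here, no measured pair shows this change, so the direction is open, and only a small step is expected, a 1.2-fold higher number from compound 2 to compound 3 (0.07 log units; within the scatter), most likely within the scatter. For compound 3 in this assay a value of 5000 nM is estimated, expected to fall between 1500 nM and 20000 nM.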

Compound 3, half-maximal effective concentration: > 50000 nM
Compound 3 was reported as a limit; the forecaster's own chance of this, stated with the estimate: 10%; middle value at least 10-fold (1.00 log units) away from the limit.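

On this saturated chain carbon, the group carried matters in this assay: methylcarbamoyl in place of 2-hydroxyethyl gives an at least 11-fold higher number from compound 2 to compound 3 (1.06 log units; beyond the scatter). The two groups have the same hydrogen-bond donor and acceptor counts, so these counts alone do not keep the read-out level. The reading for compound 3 is a limit of the assay, not a number: the limit of > 50000 nM in this assay, at which 1 of the 3 values shown sits.

The compounds shown do not separate the carbonyl from the methyl on the amide nitrogen as the part that matters. Going by these compounds, how a primary amide, a carboxylic acid or a longer hydroxyalkyl chain would read on this carbon also stays open.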